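Oxygen for sulfur in the ring on the sulfonyl chain

A few compounds are considered here, and "the series" means these few. Any claim that something is new, unique, unknown or untested is made for them only; others in the source may bear on it.

Measured compounds, with their results in a functional assay, read by Griess assay, with a stated time of 150 min, tested at 75 ug/mL; on this read-out higher numbers stand for a stronger effect at the one concentration tested and lower numbers for a weaker effect:
compound 1 `COc1ccc(C2=NN(c3ccccc3)C(c3ccc(C)cc3)C2S(=O)(=O)CC2=NCCO2)cc1`: 64.9%
compound 2 `COc1ccc(C2=NN(c3ccccc3)C(c3ccc(C)cc3)C2S(=O)(=O)CC2=NCCS2)cc1`: 44.9%
compound 3 `O=S(=O)(CC1=NCCS1)C1=NNCC1c1ccc(Cl)cc1`: "not active" (no number reported) (no number was reported)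

Compound 1 and compound 2 share one core and differ only by a group of 5 heavy atoms (3 carbon, 1 nitrogen, 1 oxygen; one five-membered non-aromatic ring with 2 hetero atoms) in place of a group of 5 heavy atoms (3 carbon, 1 nitrogen, 1 sulfur; one five-membered non-aromatic ring with 2 hetero atoms), on a saturated chain carbon bound to a sulfonyl sulfur. This change gave a number 20 percentage points higher from compound 2 to compound 1 (beyond the scatter) in this assay. Compound 4 `O=S(=O)(CC1=NCCO1)C1=NNCC1c1ccc(Cl)cc1` is not yet measured. It is related to compound 3 by the same kind of change, (a group of 5 heavy atoms (3 carbon, 1 nitrogen, 1 oxygen; one five-membered non-aromatic ring with 2 hetero atoms) in place of a group of 5 heavy atoms (3 carbon, 1 nitrogen, 1 sulfur; one five-membered non-aromatic ring with 2 hetero atoms), on a saturated chain carbon bound to a sulfonyl sulfur), at the same place, on a saturated chain carbon bound to a sulfonyl sulfur. The difference between the core of compound 3 and the core of compound 2 is not broken down here, and compound 3 carries no number, only a report of no activity. Whether the same change moves a weaker core by the same amount cannot be read from two compounds alone. Compound 4 is therefore estimated to sit low in this assay, near 15%, somewhere between 0% and 40%, with a real chance that it too is reported as not active.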

Compound 4, a percentage reported as activity, at one concentration (the size of the read-out at that concentration, not a potency): "not active" (no number reported)
Compound 4 has no reported number here; there is nothing to compare the estimate with.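

Compound 3 and compound 4 are both reported as not active in this assay, with no number for either, so no new step can be read from this pair. Nothing shown here explains this result. The compounds shown leave open whether the oxygen-for-sulfur change has any effect on this smaller core.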